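Replacing the dimethylcarbamoyl group with a methyl-oxadiazole ring

The source may report more compounds than this note shows. Statements on the series, on what has been measured and on what is new or still open speak of the compounds shown alone.

Three compounds have been measured in an assay on isolated protein for inhibition of Norepinephrine transporter (Rattus norvegicus), read by radioligand binding; a lower number here means a stronger inhibitor, a higher number a weaker inhibitor:
compound 1, `CN1CCC(c2ccc(Cl)cc2)C(C[S+]([O-])CCO)C1`, gives 42 nM;
compound 2, `CN1CCC(c2ccc(Cl)cc2)C(C[S+]([O-])CC(=O)NO)C1`, gives 12 nM;
compound 3, `CN1CCC(c2ccc(Cl)cc2)C(C[S+]([O-])CC(=O)N(C)C)C1`, gives 1250 nM.

Compound 3 is the weakest of the three: a 30-fold higher number from compound 1 to compound 3 (1.47 log units; beyond the scatter), and a 100-fold higher number from compound 2 to compound 3 (2.02 log units; beyond the scatter). Compound 4, `Cc1noc(C[S+]([O-])CC2CN(C)CCC2c2ccc(Cl)cc2)n1`, changes that weak point: 3-methyl-1,2,4-oxadiazol-5-yl in place of dimethylcarbamoyl on a saturated chain carbon bound to a sulfur. For the measured compounds named here, no measured step involves the oxadiazole itself, so the expectation rests on the two steps into compound 3, both large, which show that what sits on the saturated chain carbon bound to the sulfur can shift this assay strongly, and that compound 3 carries the least favourable group seen. Removing it is expected to give a 4.2-fold lower number from compound 3 to compound 4 (0.62 log units; beyond the scatter). Compound 4 is therefore estimated at 300 nM, with a range from 60 nM to 1500 nM.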

Compound 4, inhibition constant: 218 nM
Compound 4: middle estimate off by 1.4-fold (0.14 log units), on the high side, and the stated range covers the measured number.
By their numbers in this assay, from the lowest: compound 2; then compound 1; then compound 4; then compound 3.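

In this assay, the 3-methyl-1,2,4-oxadiazol-5-yl ring is better tolerated on this saturated chain carbon bound to a sulfur than dimethylcarbamoyl (a 5.7-fold lower number from compound 3 to compound 4 (0.76 log units; beyond the scatter)). It still does not match hydroxymethyl (a 5.2-fold higher number from compound 1 to compound 4 (0.72 log units; beyond the scatter)) or hydroxycarbamoyl (an 18-fold higher number from compound 2 to compound 4 (1.26 log units; beyond the scatter)). The two groups counted with no hydrogen-bond donors therefore give the two highest numbers of the four compounds.

No supporting measurement shows what lies behind these steps. Going by these compounds, whether a carboxylic acid, an amine, or the oxadiazole ring without its methyl would come closer to compound 2 remains open.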